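Pyridyl isomer swap on the biaryl tail of the benzimidazole series

The source may report more compounds than this note shows. Statements on the series, on what has been measured and on what is new or still open speak of the compounds shown alone.

Compound 2 `CS(=O)(=O)c1ccc2nc(-c3ccc(-c4cccnc4)cc3)[nH]c2c1` gives 425 nM in an assay on isolated protein for inhibition of acyl-CoA desaturase 1 (Rattus norvegicus) (on this read-out higher numbers stand for weaker inhibition and lower numbers for stronger inhibition), the highest of the two numbers available; the nearest is compound 1 `CS(=O)(=O)c1ccc2nc(-c3ccc(-c4ccc(F)cc4)cc3)[nH]c2c1`, which in this assay gives 25 nM. Within the data shown here, the only step recorded so far, from compound 1 to compound 2, is a 17-fold higher number from compound 1 to compound 2 (1.23 log units; beyond the scatter) and concerns the exchange of the 4-fluorophenyl for a pyridyl group. Compound 3 `CS(=O)(=O)c1ccc2nc(-c3ccc(-c4ccccn4)cc3)[nH]c2c1` differs from compound 2 by pyridin-2-yl in place of pyridin-3-yl on an aromatic carbon; both compounds carry the same atoms, joined differently. Among the measured compounds shown here, no measured step touches the move of the ring nitrogen within the pyridyl group itself, so the measured change from compound 1 to compound 2 bears on it only loosely, as it shows that the tail ring is a sensitive position in this assay. Without a measured pair for a pyridyl isomer swap the expectation is no step beyond the scatter, and the estimate for compound 3 in this assay is 400 nM, within 110 nM to 1500 nM, corresponding to an expected step of a 1.1-fold lower number from compound 2 to compound 3 (0.03 log units; within the scatter).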

Compound 3, half-maximal inhibitory concentration: 1710 nM
For compound 3 the middle estimate is 4.3-fold (0.63 log units) below the measured one, outside the stated range (above it).
By their numbers in this assay, from the lowest: compound 1; then compound 2; then compound 3.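

Moving the ring nitrogen within the pyridyl tail is not a neutral exchange in this assay, since pyridin-2-yl in place of pyridin-3-yl gives a 4.0-fold higher number from compound 2 to compound 3 (0.60 log units; beyond the scatter) even though the two compounds carry the same atoms. Measured against the 4-fluorophenyl tail, the change amounts to a 68-fold higher number from compound 1 to compound 3 (1.84 log units; beyond the scatter) and places compound 3 highest of the three, so the pyridyl tails are not equivalent at this position and the place of the ring nitrogen alters the read-out on top of the exchange of the fluorophenyl ring for a pyridyl ring. Nothing available here bears on why the two pyridyl isomers differ.

The compounds shown leave open where pyridin-4-yl, or an unsubstituted phenyl ring, would fall relative to compound 1 and compound 3 in this assay. On these data alone, it also remains open whether the order of pyridin-3-yl and pyridin-2-yl would persist with a methoxy group or an amine on the pyridyl ring.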